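This account rests on a few compounds, and the source may have more. Where it says the series, first, only, none or still open, it means among the compounds named here.

Three compounds have been measured in a functional assay on MGC-803 cells (Homo sapiens) for inhibition, read by sulforhodamine B assay; a lower number here means a stronger inhibitor, a higher number a weaker inhibitor:

- Compound 1 `O=C1C(N2CCCCC2)=CC(=O)c2c1nc1n2[C@H]2OC[C@@H](O)[C@H]2OC1`: > 4000 nM, a limit and not a number
- Compound 2 `CCOc1ccc(NC2=CC(=O)c3c(nc4n3[C@H]3OC[C@@H](O)[C@H]3OC4)C2=O)cc1`: 2090 nM
- Compound 3 `O=C1C(NCc2ccccc2)=CC(=O)c2c1nc1n2[C@H]2OC[C@@H](O)[C@H]2OC1`: 3490 nM

Compound 3 sits level with compound 2, with a 1.7-fold higher number from compound 2 to compound 3 (0.22 log units; within the scatter). Against the limit, the data show an at least 1.1-fold lower number from compound 1 to compound 3 (0.05 log units; that floor lies within the scatter).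

Compound 4 `O=C1C(NC2CCCCC2)=CC(=O)c2c1nc1n2[C@H]2OC[C@@H](O)[C@H]2OC1` keeps the shared core of compound 3 but carries cyclohexyl in place of benzyl on an amine nitrogen. Both measured steps changed the group at this same place on the core, and neither moved beyond the scatter, so no step beyond the scatter is expected here. The expected change is a 1.0-fold higher number from compound 3 to compound 4 (0.00 log units; within the scatter). Compound 4 is estimated at 3500 nM, with an expected range of 1800 nM to 6500 nM.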

Compound 4, half-maximal inhibitory concentration: > 8000 nM
Compound 4 gave a limit, no number; the forecaster's own chance of this, stated with the estimate: 30%; at least 2.2-fold (0.35 log units) between middle value and limit.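

In this assay compound 4 gives > 8000 nM, a limit and not a number. Even so, this amine nitrogen now shows a change beyond the scatter, which no earlier step did: the non-aromatic cyclohexyl gives an at least 2.2-fold higher number from compound 3 to compound 4 (0.36 log units; beyond the scatter) and an at least 3.8-fold higher number from compound 2 to compound 4 (0.58 log units; beyond the scatter). The step from compound 1 to compound 4 cannot be read, since both values are limits.

Going by these compounds, whether the loss of the aromatic ring is what matters stays open. A straight hexyl chain or a pyridine ring on this nitrogen would help to separate ring type from size.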